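Piperidine in Place of Cyclopropylpiperazine: An Untested Step

This account rests on a few compounds, and the source may have more. Where it says the series, first, only, none or still open, it means among the compounds named here.

compound 1 `CCOc1ccccc1C(=O)NCC1(N2CCN(CC)CC2)CCCCC1` — 158 nM
compound 2 `CCOc1ccccc1C(=O)NCC1(N2CCN(C3CC3)CC2)CCCCC1` — 316 nM

In an assay on HEK293 cells for inhibition of potassium/sodium hyperpolarization-activated cyclic nucleotide-gated channel 4 (Homo sapiens), with a stated time of 30 min (a higher number here means a weaker inhibitor, a lower number a stronger inhibitor), compound 1 gives 158 nM and compound 2 gives 316 nM; compound 2 holds the highest of the two numbers, but a 2.0-fold higher number from compound 1 to compound 2 (0.30 log units; within the scatter). Compound 3 `CCOc1ccccc1C(=O)NCC1(N2CCCCC2)CCCCC1` awaits measurement; it differs from compound 2 by piperidin-1-yl in place of 4-cyclopropylpiperazin-1-yl on a saturated ring carbon. Among the measured compounds shown here, the one measured step only exchanges the group on the amine nitrogen of the piperazine, so it gives no direct guide to removing that ring. Lacking such a guide, the author expects compound 3 to sit near compound 2, with a wide range: 500 nM, between 150 nM and 1800 nM, a step of a 1.6-fold higher number from compound 2 to compound 3 (0.20 log units; within the scatter).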

Compound 3, half-maximal inhibitory concentration: 39800 nM
Compound 3: the middle estimate sits 80-fold (1.90 log units) below what was measured; measured number above the stated range.
By their numbers in this assay, from the lowest: compounds 1 and 2 (each within the scatter of the next); then compound 3.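

Replacing the substituted piperazine on the saturated ring carbon with piperidin-1-yl gives a 130-fold higher number from compound 2 to compound 3 (2.10 log units; beyond the scatter) and a 250-fold higher number from compound 1 to compound 3 (2.40 log units; beyond the scatter) in this assay. The exchange on the piperazine nitrogen stayed within the scatter, whereas this change, which removes that nitrogen and its substituent together, does not, so this position responds far more to the ring than to the ethyl or cyclopropyl group. No supporting data explain the loss. As far as these compounds go, whether the nitrogen or its substituent matters more remains open. An unsubstituted piperazine or a 4-ethylpiperidine would separate the two.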